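Methylated benzylamide variant of a pyrazole dihydroxyacid

The source may report more compounds than this note shows. Statements on the series, on what has been measured and on what is new or still open speak of the compounds shown alone.

Measured compounds:
compound 1 `CC(C)c1c(C(=O)NCc2ccccc2)nn(-c2ccc(F)cc2)c1OC[C@@H](O)C[C@@H](O)CC(=O)O` — 880 nM
compound 2 `COc1cc(CN(C)C(=O)c2nn(-c3ccc(F)cc3)c(OC[C@@H](O)C[C@@H](O)CC(=O)O)c2C(C)C)cc(OC)c1` — "not determined" (no result reported)

Compound 1 carries a benzylamino group on the carbonyl carbon of the shared core. Among the compounds with values here, in a functional assay on L6 cells (Rattus norvegicus) for inhibition (on this read-out lower numbers stand for stronger inhibition and higher numbers for weaker inhibition), compound 1 gives 880 nM, and this is the only number available; in this assay compound 2, with its methyl(3,5-dimethoxybenzyl)amino group, gives "not determined" (no result reported), so compound 1 cannot be placed against anything else.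

Compound 3 `Cc1cccc(CN(C)C(=O)c2nn(-c3ccc(F)cc3)c(OC[C@@H](O)C[C@@H](O)CC(=O)O)c2C(C)C)c1` differs from compound 1 in one place: methyl(3-methylbenzyl)amino in place of benzylamino on a carbonyl carbon. Within the data shown here, with no measured pair showing this change, the size of the step is uncertain. A modest shift toward weaker inhibition is expected, with a 1.7-fold higher number from compound 1 to compound 3 (0.23 log units; within the scatter) as the estimated step, which may still lie within the scatter. Compound 3 is therefore expected to give about 1500 nM in this assay, with a range from 400 nM to 6000 nM.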

Compound 3, half-maximal inhibitory concentration: 18500 nM
Beside the measured number, compound 3's estimate is 12-fold (1.09 log units) below it, outside the stated range (above it).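

In this assay, within the data shown here, the change on the carbonyl carbon from benzylamino to methyl(3-methylbenzyl)amino gives a 21-fold higher number from compound 1 to compound 3 (1.32 log units; beyond the scatter), the first evidence that this position can respond strongly, with a large step toward weaker inhibition. The entering group differs in two ways at once: it has no hydrogen-bond donor where benzylamino has one, and it adds carbon atoms, so this single step cannot be divided between those differences. The data shown offer no measurement that explains the step.

Steps involving compound 2 cannot be read, which leaves the methyl(3,5-dimethoxybenzyl)amino group unplaced. From the compounds shown here alone, it also remains open whether methylbenzylamino or 3-methylbenzylamino alone would reproduce the step, and how an ethyl group on the amide nitrogen or a chlorine on the benzyl ring would read.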